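Amino replaced by nitro: expected loss of the low number

The source may hold more compounds than are shown below. What is called first, only, known or untested is meant among the compounds shown, and "the series" means these compounds.

In a functional assay on MCF7 cells (Homo sapiens) for inhibition, read by CCK-8 assay, with a stated time of 48 h (on this read-out lower numbers stand for stronger inhibition and higher numbers for weaker inhibition), compound 3 (`COc1ccc(-c2cc3nccc(-c4cc(OC)c(OC)c(OC)c4)n3n2)cc1N`) gives 27 nM, the lowest of three numbers. Compound 1 (`COc1ccc(-c2cc3nccc(-c4cc(OC)c(OC)c(OC)c4)n3n2)cc1`) gives 125 nM and compound 2 (`COc1ccc(-c2cc3nccc(-c4cc(OC)c(OC)c(OC)c4)n3n2)cc1F`) gives 183 nM. Compound 4 (`COc1ccc(-c2cc3nccc(-c4cc(OC)c(OC)c(OC)c4)n3n2)cc1[N+](=O)[O-]`) has nitro in place of amino on an aromatic carbon, ortho to a methoxy group: nitro in place of amino on an aromatic carbon.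

Among the compounds with values here, two measured steps bear on this: a 4.6-fold lower number from compound 1 to compound 3 (0.67 log units; beyond the scatter) and a 6.8-fold lower number from compound 2 to compound 3 (0.83 log units; beyond the scatter), both beyond the scatter. By contrast, a 1.5-fold higher number from compound 1 to compound 2 (0.17 log units; within the scatter) stays within it. Within the data shown here, only compound 3 carries amino, and no nitro compound has been measured. Compound 4 is therefore expected to return towards compound 1 and compound 2.

The expected step, to a higher number, is a 5.6-fold higher number from compound 3 to compound 4 (0.74 log units; beyond the scatter). The estimate for compound 4 is 150 nM, with an expected range of 50 nM to 450 nM.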

Compound 4, half-maximal inhibitory concentration: > 10000 nM
Compound 4 gave a limit, no number; the forecaster's own chance of this, stated with the estimate: 2%; middle value at least 66-fold (1.82 log units) from the limit.
By their numbers in this assay, from the lowest: compound 3; then compounds 1 and 2 (each within the scatter of the next). At a limit, above all of these: compound 4.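

In this assay, compound 4 sits at a limit, not a number: the limit of > 10000 nM in this assay, at which 1 of the 4 values shown sits. The steps are large and beyond the scatter: an at least 370-fold higher number from compound 3 to compound 4 (2.56 log units; beyond the scatter), an at least 80-fold higher number from compound 1 to compound 4 (1.90 log units; beyond the scatter) and an at least 54-fold higher number from compound 2 to compound 4 (1.73 log units; beyond the scatter). Hydrogen and fluoro had left this position looking tolerant, with only amino standing apart, but nitro shows that a change here can also cost heavily, well past both.

Going by these compounds, what separates amino from nitro stays open. A hydroxyl, methylamino or acetamido group at this place would test whether the low number belongs to amino alone.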